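This account rests on a few compounds, and the source may have more. Where it says the series, first, only, none or still open, it means among the compounds named here.

Measured compounds in an assay on isolated protein for inhibition of DNA topoisomerase 1 (Homo sapiens), with a stated time of 30 min, tested at 20 uM; on this read-out lower numbers stand for a weaker effect and higher numbers for a stronger effect at the one concentration tested:
- compound 1, `Oc1cccc(-c2cc(-c3cccs3)cc(-c3ccccc3O)n2)c1`, gives 1.5%
- compound 2, `Oc1cccc(-c2cc(-c3ccccn3)cc(-c3ccccc3O)n2)c1`, gives 0.1%

On these two numbers compound 2 sits alongside compound 1: the two values lie within the scatter of each other, and both show little effect at the concentration tested. Within the data shown here, the only measured step, a number 1.4 percentage points lower from compound 1 to compound 2 (within the scatter), exchanges one aromatic ring for another on the shared core and leaves the read-out essentially unchanged.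

Compound 3, `Oc1cccc(-c2cc(-c3cccnc3)cc(-c3ccccc3O)n2)c1`, is the next compound in this series. It differs from compound 2 in one place: pyridin-3-yl in place of pyridin-2-yl on an aromatic carbon. The step from compound 1 to compound 2 bears on this change most closely, since it also swaps an aromatic ring at the same place on the core, and it was within the scatter. Among the measured compounds shown here, no step that moves a ring nitrogen from one position to another has been measured here, so nothing in the data points to a change beyond the scatter. Compound 3 is therefore estimated at 1.5%, within a range of 0% to 8%, which means an expected step of a number 1.4 percentage points higher from compound 2 to compound 3 (within the scatter).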

Compound 3, a percentage reported as inhibition, at one concentration (the size of the read-out at that concentration, not a potency): 0%
Compound 3: middle estimate off by 1.5 percentage points, on the high side; low and high end bracket the measured number.
By their numbers in this assay, from the lowest: compounds 3, 2 and 1 (each within the scatter of the next).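

In this assay, among these compounds, moving the ring nitrogen of the pyridine from one position to another gives a number 0.1 percentage points lower from compound 2 to compound 3 (within the scatter) and so leaves the read-out in the same place, which shows for the first time that the position of this nitrogen makes no visible difference at this place on the shared core, opposite the ring nitrogen. Comparing pyridin-3-yl directly with thiophen-2-yl gives a number 1.5 percentage points lower from compound 1 to compound 3 (within the scatter) and confirms the picture: the three aromatic rings tried here, with sulfur or with nitrogen in two positions, cannot be told apart, and all three compounds show little effect at the one concentration tested. Nothing measured here offers an explanation for this flat result.

Going by these compounds, what remains open is whether any group at this place can raise the read-out at all, for example pyridin-4-yl, an amine, a carboxylic acid or a longer alkyl chain in place of these aromatic rings. The compounds shown also leave open what happens when the 2-hydroxyphenyl and 3-hydroxyphenyl groups are changed, since both stay the same throughout this set.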